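Hydroxyphenyl Analogue in the Maltase-Glucoamylase Series

A few compounds are considered here, and "the series" means these few. Any claim that something is new, unique, unknown or untested is made for them only; others in the source may bear on it.

Compound 1 `O=C(N/N=C/c1ccc([N+](=O)[O-])cc1)c1ccc(-c2nc3ccccc3s2)cc1`: 26400 nM
Compound 2 `COc1ccc(/C=N/NC(=O)c2ccc(-c3nc4ccccc4s3)cc2)cc1`: 18300 nM

In an assay on isolated protein for inhibition of Maltase-glucoamylase (Homo sapiens), with a stated time of 15 min (on this read-out higher numbers stand for weaker inhibition and lower numbers for stronger inhibition), compound 2 stands lowest of the two numbers, with compound 1 nearest, though the step of a 1.4-fold lower number from compound 1 to compound 2 (0.16 log units; within the scatter) lies within the scatter. Compound 3 `O=C(N/N=C/c1cccc(O)c1)c1ccc(-c2nc3ccccc3s2)cc1` differs from compound 2 by 3-hydroxyphenyl in place of 4-methoxyphenyl on a carbon with a double bond to nitrogen. For the measured compounds named here, no measured step bears directly on this change; the only step known, a 1.4-fold lower number from compound 1 to compound 2 (0.16 log units; within the scatter), concerns another group and is within the scatter. Compound 3 is therefore expected to show no step beyond the scatter, a 1.0-fold lower number from compound 2 to compound 3 (0.01 log units; within the scatter). The estimate for compound 3 in this assay is 18000 nM, expected between 7000 nM and 45000 nM.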

Compound 3, half-maximal inhibitory concentration: 9210 nM
Estimate against measurement, compound 3: 2.0-fold (0.29 log units) above, and the stated range covers the measured number.
By their numbers in this assay, from the lowest: compounds 3, 2 and 1 (each within the scatter of the next, the first and the last beyond it).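

In this assay, for the compounds shown here, 3-hydroxyphenyl gives the first step at this position that passes the scatter, a 2.9-fold lower number from compound 1 to compound 3 (0.46 log units; beyond the scatter), with 3-hydroxyphenyl in place of 4-nitrophenyl. Against 4-methoxyphenyl the same group stays within the scatter, a 2.0-fold lower number from compound 2 to compound 3 (0.30 log units; within the scatter), so compound 2 and compound 3 cannot be told apart here. Nothing at hand accounts for either step. On these data alone, whether the step from compound 1 belongs to the hydroxy group itself or to where it sits on the ring stays open, as does how an amine or a carboxylic acid on this phenyl ring would read.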